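The source may hold more compounds than are shown below. What is called first, only, known or untested is meant among the compounds shown, and "the series" means these compounds.

Of the compounds shown here, two have been measured so far. Compound 1, `COc1ccc(-n2nc(Sc3ccc(Cl)cc3)cc(CC[C@@H](C)NC(=O)[C@H]3CCNC[C@@H]3c3ccc(Cl)cc3Cl)c2=O)cc1`, gives 2400 nM in a functional assay with Melanocortin receptor 4 (Homo sapiens) as the target, read by cAMP accumulation; on this read-out higher numbers stand for an effect only at larger amounts of compound and lower numbers for an effect already at smaller amounts. Compound 2, `COc1ccc(-n2nc(Sc3ccc(Cl)cc3)cc(CC[C@@H](C)NC(=O)[C@H]3CNC[C@@H]3c3ccc(F)cc3F)c2=O)cc1`, gives 200 nM in this assay, the lower of the two numbers, and the gap between compound 2 and compound 1 lies beyond the usual scatter. Compound 1 and compound 2 differ in more than one place, so their two values alone cannot be tied to a single change.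

Compound 3, `COc1ccc([C@H]2CNC[C@@H]2C(=O)N[C@H](C)CCc2cc(Sc3ccc(Cl)cc3)nn(-c3ccc(OC)cc3)c2=O)cc1`, has not yet been tested. It keeps the shared core of compound 2 and differs only by 4-methoxyphenyl in place of 2,4-difluorophenyl on a saturated ring carbon. Going by the values given here, no measured pair isolates this swap, so the direction of the step is uncertain. Some weakening is expected, with a step from compound 2 to compound 3 of about a 3.0-fold higher number from compound 2 to compound 3 (0.48 log units; beyond the scatter) in this assay. Compound 3 is therefore estimated at 600 nM, within a range of 150 nM to 2500 nM.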

Compound 3, half-maximal effective concentration: 430 nM
Estimate against measurement, compound 3: 1.4-fold (0.14 log units) above; measured number inside the range.
By their numbers in this assay, from the lowest: compound 2; then compound 3; then compound 1.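

In this assay, going by these compounds alone, the change from 2,4-difluorophenyl to 4-methoxyphenyl on the saturated ring carbon gives a 2.2-fold higher number from compound 2 to compound 3 (0.33 log units; beyond the scatter) and is the first step here that isolates a single change at this position. The step is modest, so this carbon accepts either of these two substituted aromatic rings, each with 8 heavy atoms, with only a limited weakening of the effect. Nothing measured here explains the step.

The swap removes two fluorine atoms and adds a methoxy group in one move, so it remains open which of these accounts for the step. A plain phenyl or a 4-fluorophenyl group on the same carbon would help separate the two, while a much smaller group such as methyl would test whether an aromatic ring is needed there at all.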